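Methyl to Chloro on the Aryl Ring: Expected Effect

The source may report more compounds than this note shows. Statements on the series, on what has been measured and on what is new or still open speak of the compounds shown alone.

Measured compounds:
Compound 1, `CCCS(=O)(=O)Nc1ccc(F)c(C(=O)c2n[nH]c3ncc(-c4cccc(Cl)c4)cc23)c1F`, gives 40% in an assay for binding affinity to dual specificity mitogen-activated protein kinase kinase 4 (Homo sapiens), read by KINOMEscan, tested at 100 nM; on this read-out higher numbers stand for a weaker effect at the one concentration tested and lower numbers for a stronger effect.
Compound 2, `CCCS(=O)(=O)Nc1ccc(F)c(C(=O)c2n[nH]c3ncc(-c4cccc(C)c4)cc23)c1F`, gives 15% in this assay.
Compound 3, `CCCS(=O)(=O)Nc1ccc(F)c(C(=O)c2n[nH]c3ncc(-c4ccc(S(N)(=O)=O)cc4C)cc23)c1F`, gives 3.1% in this assay.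

All three share one core and differ only in the aryl ring hanging from it. Compound 2 and compound 1 differ by chloro in place of methyl on an aromatic carbon, and that step reads a number 25 percentage points higher from compound 2 to compound 1 (beyond the scatter), so the chloro compound binds more weakly at the single concentration tested. Compound 3 carries a different aryl ring altogether; against compound 2 it differs by 2-methyl-4-sulfamoylphenyl in place of 3-methylphenyl on an aromatic carbon, and the step is a number 11.9 percentage points lower from compound 2 to compound 3 (beyond the scatter). Against compound 1 the step is a number 36.9 percentage points lower from compound 1 to compound 3 (beyond the scatter), which leaves compound 3 with the lowest number of the three.

Compound 4, `CCCS(=O)(=O)Nc1ccc(F)c(C(=O)c2n[nH]c3ncc(-c4ccc(S(N)(=O)=O)cc4Cl)cc23)c1F`, has not been measured. It differs from compound 3 by chloro in place of methyl on an aromatic carbon. Among the measured compounds shown here, this is the same kind of change as the one from compound 2 to compound 1, but not the same: there the chloro sat meta to a large group, here it sits ortho to a large group and meta to a sulfamoyl group. The earlier step raised the number by a modest amount, and compound 3 starts so low that little room remains downward. For compound 4 a rise of a number 8.9 percentage points higher from compound 3 to compound 4 (within the scatter) in this assay is expected, resting on compound 3 at 3.1% and on the step of a number 25 percentage points higher from compound 2 to compound 1 (beyond the scatter). The estimate for compound 4 is 12%, between 2% and 35%.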

Compound 4, a percentage reported as activity, at one concentration (the size of the read-out at that concentration, not a potency): 3.4%
Estimate against measurement, compound 4: 8.6 percentage points above, within the range that was stated.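

The swap of methyl for chloro does not carry over unchanged from one aryl ring to the other in this assay; the two results differ clearly: the same change on two cores in this assay, a number 25 percentage points higher (beyond the scatter) from compound 2 to compound 1 and a number 0.3 percentage points higher (within the scatter) from compound 3 to compound 4, 24.7 percentage points apart, beyond the scatter of two such steps On the sulfamoyl-bearing ring the swap reads a number 0.3 percentage points higher from compound 3 to compound 4 (within the scatter), so compound 3 and compound 4 cannot be told apart here, and compound 4 stays well under the two compounds without the sulfamoyl group, with a number 11.6 percentage points lower from compound 2 to compound 4 (beyond the scatter) and a number 36.6 percentage points lower from compound 1 to compound 4 (beyond the scatter). Among the compounds shown here, this does not show which difference between the two rings, the sulfamoyl group or the place of the swapped group, accounts for the gap, and with only two pairs it gives no rule for how the swap will behave on any further ring.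

Still open, going by these compounds, is whether the swap would again make no clear difference if an amine or a carboxylic acid stood in place of the sulfamoyl group. Also open, on these data alone, is how a bromo or an ethyl group would read at the same spot as the chloro and the methyl on the 2-chloro-4-sulfamoylphenyl and 2-methyl-4-sulfamoylphenyl rings.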